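Moving the amino group from compound 2 to compound 3

This account rests on a few compounds, and the source may have more. Where it says the series, first, only, none or still open, it means among the compounds named here.

- compound 1 `COc1cc(OC)c(/C=C/S(=O)(=O)Cc2ccc(F)c(N)c2)c(OC)c1` gives 2500 nM
- compound 2 `COc1ccc(CS(=O)(=O)/C=C/c2c(OC)cc(OC)cc2OC)c(N)c1` gives 25 nM

In a functional assay on DU-145 cells (Homo sapiens) for cytotoxicity, read by trypan blue exclusion, with a stated time of 96 h (a lower number here means a stronger inhibitor, a higher number a weaker inhibitor), compound 2 has the lower of the two numbers, 25 nM. Compound 3 `COc1cc(OC)c(/C=C/S(=O)(=O)Cc2ccc(OC)c(N)c2)c(OC)c1` differs from it as follows: 3-amino-4-methoxyphenyl in place of 2-amino-4-methoxyphenyl on a saturated chain carbon bound to a sulfonyl sulfur, with 3-amino-4-methoxyphenyl in place of 2-amino-4-methoxyphenyl on a saturated chain carbon bound to a sulfonyl sulfur. Within the data shown here, only one measured step bears on this: a 100-fold lower number from compound 1 to compound 2 (2.00 log units; beyond the scatter). On these data alone, that step changed the amino placement and swapped fluoro for methoxy together, so the share of each is unknown. Compound 3 keeps the methoxy, so a moderate rise, not the full step, is expected, an estimated 2.0-fold higher number from compound 2 to compound 3 (0.30 log units; within the scatter). Compound 3 is expected at 50 nM, within an estimated range of 10 nM to 400 nM.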

Compound 3, half-maximal inhibitory concentration: 4 nM
Estimate against measurement, compound 3: 13-fold (1.10 log units) above, and the stated range ends above it.
By their numbers in this assay, from the lowest: compound 3; then compound 2; then compound 1.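

Compound 3 separates two changes that the earlier pair left tangled in this assay and shows how each acts on its own. With the methoxy kept, moving the amino group alone gives a 6.3-fold lower number from compound 2 to compound 3 (0.80 log units; beyond the scatter) in favour of 3-amino-4-methoxyphenyl. With the amino group kept, methoxy in place of fluoro on an aromatic carbon gives a much larger change: a 630-fold lower number from compound 1 to compound 3 (2.80 log units; beyond the scatter) and thus the main share of the gain. Nothing measured here says why either change works. Still open, on these data alone, is whether an ethoxy group could replace the methoxy, or a dimethylamino group the amino group, at this level.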